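Cyclohexenyl for Cyclopentyl on a Triple-Bonded Carbon

This account rests on a few compounds, and the source may have more. Where it says the series, first, only, none or still open, it means among the compounds named here.

Compound 1 `O=C(O)CCc1ccc(C#CC2CCCC2)cc1` was tested in a functional assay on 1321-N1 cells for agonist activity at Free fatty acid receptor 1 (Homo sapiens), read by calcium flux, with a stated time of 0.4 s (a higher number here means a larger maximal response, a lower number a smaller maximal response), where compound 1 gives 94%. Compound 2 `C/C=C(/C)C#Cc1ccc(CCC(=O)O)c(F)c1` was examined in the same way, and in this assay compound 2 gives 103%. Compound 1 thus stands beside compound 2 with a number that lies within the usual scatter of repeated measurements of the other, so nothing separates the two. Compound 3 `O=C(O)CCc1ccc(C#CC2=CCCCC2)cc1` has not yet been measured. It differs from compound 1 in one place: cyclohex-1-en-1-yl in place of cyclopentyl on a triple-bonded carbon. For the measured compounds named here, since compound 1 reaches 94% and compound 2 reaches 103%, both near the reference, and no step between measured compounds is known that would show what such a change does, the change from compound 1 to compound 3 is expected to bring no step beyond the scatter, namely a number 4 percentage points higher from compound 1 to compound 3 (within the scatter). For compound 3 in this assay the estimate is 98%, with a range from 82% to 114%.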

Compound 3, largest response reached (reported as efficacy), in percent of the reference or control that the assay uses: 100%
For compound 3 the middle estimate is 2 percentage points below the measured one; the range from low to high includes it.
By their numbers in this assay, from the lowest: compounds 1, 3 and 2 (each within the scatter of the next).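

In this assay, for the compounds shown here, the change to cyclohex-1-en-1-yl in place of cyclopentyl on a triple-bonded carbon gives a number 6 percentage points higher from compound 1 to compound 3 (within the scatter) and is the first step that can be read at this position. It shows that the maximal response of compound 1 and compound 3 cannot be told apart, although the entering ring is six-membered and brings a double bond outside aromatic rings. No measurement at hand offers an explanation for this result.

The compounds shown leave open whether a phenyl ring or an amine on the same triple-bonded carbon would also leave the maximal response within the scatter. They also leave open whether compound 1 and compound 3 need similar concentrations to reach that response, as only the largest response is given here.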